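Working notes: exchanging the phenyl group in a small series

The source may hold more compounds than are shown below. What is called first, only, known or untested is meant among the compounds shown, and "the series" means these compounds.

- Compound 1 `COc1ccc(C2=NO[C@]3(C2)C(=O)O[C@@H]2[C@H]3CC[C@H](C)[C@]3(O)C=CC(=O)[C@@]23C)cc1OC` in a physicochemical assay for lipophilicity (on this read-out lower numbers stand for lower lipophilicity and higher numbers for higher lipophilicity), gives 1.06
- Compound 2 `C[C@H]1CC[C@@H]2[C@@H](OC(=O)[C@]23CC(c2cccc([N+](=O)[O-])c2)=NO3)[C@]2(C)C(=O)C=C[C@@]12O` in this assay gives 1.37

For the measured compounds named here, compound 2 at 1.37 holds the higher of the two numbers in this assay, and the only other value is that of compound 1 at 1.06. The next compound is compound 3 `C[C@H]1CC[C@@H]2[C@@H](OC(=O)[C@]23CC(c2ccccc2Cl)=NO3)[C@]2(C)C(=O)C=C[C@@]12O`, with this change: 2-chlorophenyl in place of 3-nitrophenyl on a carbon with a double bond to nitrogen. Going by the values given here, one measured step bears on it, also an exchange of the group on the carbon with a double bond to nitrogen: a number 0.31 log units higher from compound 1 to compound 2 (beyond the scatter). That step is modest. Neither measured compound carries a 2-chlorophenyl group, so the data give no direct guide and the expectation is uncertain. An upward step somewhat larger than that modest one is expected: a number 0.43 log units higher from compound 2 to compound 3 (beyond the scatter). For compound 3 the estimated value is 1.8, with an expected range from 1.4 to 2.2.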

Compound 3, partition coefficient: 2.09
For compound 3 the middle estimate is 0.29 log units below the measured one; measured number inside the range.
By their numbers in this assay, from the lowest: compound 1; then compound 2; then compound 3.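

In this assay, for the compounds shown here, the group on the carbon with a double bond to nitrogen now covers a wider range than the single modest step from the earlier pair showed. 2-chlorophenyl in place of 3-nitrophenyl gives a further modest rise (a number 0.72 log units higher from compound 2 to compound 3 (beyond the scatter)), and 2-chlorophenyl in place of 3,4-dimethoxyphenyl gives a large one (a number 1.03 log units higher from compound 1 to compound 3 (beyond the scatter)), which places compound 3 highest of the three. Nothing measured on these compounds accounts for the size of either step.

Going by these compounds alone, whether the rise follows the chlorine itself or its place on the phenyl ring stays open, with only one chlorophenyl group among the compounds. Also open, as far as these compounds go, is where an unsubstituted phenyl, a 4-chlorophenyl or a phenyl bearing an amine or a carboxylic acid would fall on this scale.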